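Aryl sulfonyl variations on a shared core

A few compounds are considered here, and "the series" means these few. Any claim that something is new, unique, unknown or untested is made for them only; others in the source may bear on it.

Measured compounds:
compound 1 `CC1CCN(c2c(S(=O)(=O)c3ccc(F)c(Cl)c3)cnc3cc(F)ccc23)CC1` — 94%
compound 2 `CC1CCN(c2c(S(=O)(=O)c3ccccc3)cnc3cc(F)ccc23)CC1` — 87%
compound 3 `CC1CCN(c2c(S(=O)(=O)c3cc(Cl)cc(Cl)c3)cnc3cc(F)ccc23)CC1` — 87%

All three compounds were tested in an assay on isolated protein for displacement of a labelled ligand from metabotropic glutamate receptor 5 (Homo sapiens), with a stated time of 60 min, tested at 1 uM; on this read-out lower numbers stand for less inhibition and higher numbers for more inhibition at the one concentration tested (going by the name of the read-out). They share one core and differ only in the aromatic group attached to the sulfonyl sulfur. Swapping that group has so far made little difference: a number 7 percentage points lower from compound 1 to compound 2 (within the scatter) and a number 7 percentage points lower from compound 1 to compound 3 (within the scatter), and no change at the digits printed from compound 2 to compound 3 (within the scatter). Compound 3 therefore sits at the same number as compound 2, and the gap to compound 1 is within the scatter, so none of the three can be set apart from the others on this read-out.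

Compound 4 `Cc1ccc(S(=O)(=O)c2cnc3cc(F)ccc3c2N2CCC(C)CC2)cc1F` continues the same kind of exchange: 3-fluoro-4-methylphenyl in place of 3,5-dichlorophenyl on a sulfonyl sulfur. Among the compounds with values here, the steps that bear on this are the three already seen, each a change of the aromatic group on the sulfonyl sulfur, and every one of them stayed within the scatter. Within the data shown here, with no measured step pointing in either direction, the expectation is for a number 1 percentage points higher from compound 3 to compound 4 (within the scatter), that is, no movement beyond the scatter. Compound 4 is thus estimated to give 88% in this assay, with a likely range from 78% to 96%.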

Compound 4, a percentage reported as inhibition, at one concentration (the size of the read-out at that concentration, not a potency): 89%
For compound 4 the middle estimate is 1 percentage points below the measured one, within the range that was stated.
By their numbers in this assay, from the lowest: compounds 2, 3, 4 and 1 (each within the scatter of the next).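

Within the data shown here, compound 4 puts a ring carrying a methyl group on the sulfonyl sulfur, and in this assay this exchange does not separate it from any of the earlier compounds (a number 2 percentage points higher from compound 3 to compound 4 (within the scatter); a number 2 percentage points higher from compound 2 to compound 4 (within the scatter); a number 5 percentage points lower from compound 1 to compound 4 (within the scatter)). The earlier aryl groups were plain phenyl or carried only halogens, so this result extends the range of groups accepted at this position to a 3-fluoro-4-methylphenyl group, with all four compounds now within the scatter of one another. No measurement shown offers an explanation for this lack of separation.

Among these compounds, all the groups at this position so far are phenyl rings that are bare or carry halogen or methyl, so it remains open whether the number would hold with an amine or a carboxylic acid on that ring, or with a simple butyl chain in place of the ring. Each number also comes from a single concentration, which leaves open whether these compounds would differ in potency if tested across a range of concentrations.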